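Thiophen-2-yl replacing 3,4,5-trimethoxyphenyl in the series

The compounds below may be only part of what the source reports. "The series", "measured", "known", "first", "only" and "open" are said of these compounds alone.

Among the measured compounds shown here, in a functional assay on THP-1 cells (Homo sapiens) for inhibition, read by sulforhodamine B assay, with a stated time of 48 h, tested at 50 uM (a higher number here means more inhibition of growth at the concentration tested, a lower number less inhibition of growth), compound 1 (`COc1cc(/C=C/C(=O)/C=C/c2ccccc2)ccc1OCc1cn(CCCCOc2cc(=O)oc3ccccc23)nn1`) gives 36% and compound 2 (`COc1cc(/C=C/C(=O)/C=C/c2cc(OC)c(OC)c(OC)c2)ccc1OCc1cn(CCCCOc2cc(=O)oc3ccccc23)nn1`) gives 65% as the higher of the two numbers so far. Compound 3 (`COc1cc(/C=C/C(=O)/C=C/c2cccs2)ccc1OCc1cn(CCCCOc2cc(=O)oc3ccccc23)nn1`) is not yet measured. It differs from compound 2 as follows (thiophen-2-yl in place of 3,4,5-trimethoxyphenyl on a double-bonded chain carbon bound to a double-bonded chain carbon) with thiophen-2-yl in place of 3,4,5-trimethoxyphenyl on a double-bonded chain carbon bound to a double-bonded chain carbon. For the measured compounds named here, the only measured step at this place is modest (a number 29 percentage points higher from compound 1 to compound 2 (beyond the scatter)) and, read in reverse, it points to a fall of similar size in this assay when 3,4,5-trimethoxyphenyl leaves. Going by the values given here, no measurement yet covers thiophen-2-yl itself, so the size remains uncertain. The expected change is a fall (a number 23 percentage points lower from compound 2 to compound 3 (beyond the scatter)) beyond the scatter. Compound 3 is estimated at 42% with a range from 25% to 60% expected.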

Compound 3, percent growth inhibition at one concentration: 44%
Beside the measured number, compound 3's estimate is 2 percentage points below it; low and high end bracket the measured number.
By their numbers in this assay, from the lowest: compounds 1 and 3 (each within the scatter of the next); then compound 2.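

In this assay, thiophen-2-yl in place of 3,4,5-trimethoxyphenyl on a double-bonded chain carbon bound to a double-bonded chain carbon gives a number 21 percentage points lower from compound 2 to compound 3 (beyond the scatter), so a second group, not only phenyl, now stands beyond the scatter from 3,4,5-trimethoxyphenyl. Thiophen-2-yl in place of phenyl gives a number 8 percentage points higher from compound 1 to compound 3 (within the scatter), so this assay does not tell these two groups apart, and among the three groups at this place only 3,4,5-trimethoxyphenyl stands apart. No evidence at hand bears on why the groups rank this way.

The compounds shown leave open whether all three methoxy groups are needed for the higher number in compound 2, or whether a phenyl ring with a single methoxy group would match it. They also leave open how a phenyl ring carrying a dimethylamino group or a carboxylic acid would read at this place.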